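Swapping the Aryl Group on a Shared Thiourea Core

The source may report more compounds than this note shows. Statements on the series, on what has been measured and on what is new or still open speak of the compounds shown alone.

Three compounds share one core and differ only in the aryl group on a nitrogen on an aromatic ring. Compound 1 `NS(=O)(=O)c1ccc(NC(=S)Nc2ccc3ncnc(Nc4ccc(Cl)c(C(F)(F)F)c4)c3c2)cc1` gives 4500 nM in a functional assay on A549 cells (Homo sapiens) for antiproliferative activity, read by MTT assay, with a stated time of 72 h; on this read-out lower numbers stand for stronger inhibition and higher numbers for weaker inhibition. Compound 2 `NS(=O)(=O)c1ccc(NC(=S)Nc2ccc3ncnc(Nc4ccc(F)c(Br)c4)c3c2)cc1` reaches only a limit of the assay, > 40000 nM. Compound 3 `NS(=O)(=O)c1ccc(NC(=S)Nc2ccc3ncnc(Nc4ccc(C(F)(F)F)cc4)c3c2)cc1` likewise reaches only a limit, > 40000 nM, so compound 3 stands among the weaker members here, with no exact number.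

Compound 4 `Cc1cccc(Nc2ncnc3ccc(NC(=S)Nc4ccc(S(N)(=O)=O)cc4)cc23)c1` carries 3-methylphenyl in place of 4-(trifluoromethyl)phenyl on a nitrogen on an aromatic ring. Among the compounds with values here, no measured step joins these two groups directly. The nearest evidence is an at least 8.8-fold higher number from compound 1 to compound 3 (0.94 log units; beyond the scatter) and an at least 8.8-fold higher number from compound 1 to compound 2 (0.94 log units; beyond the scatter), both showing that leaving 4-chloro-3-(trifluoromethyl)phenyl costs potency, while a step that the two limits leave unreadable from compound 2 to compound 3 cannot be read. Since the limit of > 40000 nM in this assay, at which 2 of the 3 values shown sit, holds two of three values, compound 4 is expected to remain weak, with a step of an at least 1.1-fold lower number from compound 3 to compound 4 (0.05 log units; that floor lies within the scatter). Compound 4 is therefore estimated at 35000 nM, between 8000 nM and 100000 nM.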

Compound 4, half-maximal inhibitory concentration: > 40000 nM
Compound 4: only a limit was reported; the forecaster's own chance of this, stated with the estimate: 60%; middle value at least 1.1-fold (0.05 log units) away from the limit.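

In this assay, compound 4 also stops at a limit of the assay, > 40000 nM, so 3-methylphenyl, a group of carbon only, gives no measurable value at this position. Changing 4-chloro-3-(trifluoromethyl)phenyl to 3-methylphenyl gives an at least 8.8-fold higher number from compound 1 to compound 4 (0.94 log units; beyond the scatter), making this the third replacement on this nitrogen to lose the measurable activity of compound 1. The steps among compound 2, compound 3 and compound 4 cannot be read, because all three stop at the same limit: the limit of > 40000 nM in this assay, at which 3 of the 4 values shown sit.

On these data alone, what a plain phenyl or a chlorophenyl group would give on this nitrogen remains open. So does whether the measurable value of compound 1 depends on having both chlorine and trifluoromethyl on the one ring.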